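The compounds below may be only part of what the source reports. "The series", "measured", "known", "first", "only" and "open" are said of these compounds alone.

Values in a functional assay on MCF7 cells (Homo sapiens) for antiproliferative activity, read by MTT assay, with a stated time of 24 h; on this read-out lower numbers stand for stronger inhibition and higher numbers for weaker inhibition:
- compound 1 `CNC(=O)c1ccccc1Oc1nc(Nc2ccccc2F)ncc1Br`: > 50000 nM (a limit of the assay)
- compound 2 `CNC(=O)c1ccccc1Oc1nc(Nc2ccccc2OC)ncc1Br`: > 50000 nM (a limit of the assay)
- compound 3 `CNC(=O)c1ccccc1Oc1nc(Nc2ccc(C)cc2C)ncc1Br`: 44700 nM

Compound 3 is the only one of the three with an actual number. Compound 4 `CNC(=O)c1ccccc1Oc1nc(Nc2ccc(Cl)cc2F)ncc1Br` carries 4-chloro-2-fluorophenyl in place of 2,4-dimethylphenyl on a nitrogen on an aromatic ring.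

The measured steps that bear on this change are an at least 1.1-fold lower number from compound 1 to compound 3 (0.04 log units; that floor lies within the scatter) and an at least 1.1-fold lower number from compound 2 to compound 3 (0.04 log units; that floor lies within the scatter). Both are floors within the scatter, so neither sets a direction or a size.

In this assay the expected result is a 1.1-fold lower number from compound 3 to compound 4 (0.05 log units; within the scatter), with no change expected beyond the scatter.

For compound 4 the estimate is 40000 nM, with an expected range of 15000 nM to 70000 nM.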

Compound 4, half-maximal inhibitory concentration: > 50000 nM
Compound 4 gave a limit, no number; the forecaster's own chance of this, stated with the estimate: 50%; middle value at least 1.2-fold (0.09 log units) from the limit.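

Placing 4-chloro-2-fluorophenyl where 2,4-dimethylphenyl stood on the nitrogen gives an at least 1.1-fold higher number from compound 3 to compound 4 (0.04 log units; that floor lies within the scatter) and so sets no direction for this change. The steps from compound 1 and compound 2 to compound 4 cannot be read, since both ends of each are limits. Compound 4 also ends at a limit in this assay and adds to the ceiling on this series : the limit of > 50000 nM in this assay, at which 3 of the 4 values shown sit.

Still open, on these data alone, is whether a morpholine, a piperazine or a carboxylic acid in place of these substituted phenyl groups would give a value clear of that limit.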